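A few compounds are considered here, and "the series" means these few. Any claim that something is new, unique, unknown or untested is made for them only; others in the source may bear on it.

Working notes on the series.

For the measured compounds named here, the shared core carries a cyclohexyl group and a para-substituted phenyl ring in the two compounds measured so far. Compound 1 `Fc1ccc(-c2cn3ccnc3c(-c3ccc4ncn(C5CCCCC5)c4c3)n2)cc1` gives 10.3% in a functional assay on OVCAR-5 cells (Homo sapiens) for inhibition, read by sulforhodamine B assay, with a stated time of 48 h, tested at 10 uM; a higher number here means more inhibition at the concentration tested (going by the name of the read-out), a lower number less inhibition. Compound 2 `Brc1ccc(-c2cn3ccnc3c(-c3ccc4ncn(C5CCCCC5)c4c3)n2)cc1` gives 8.95% in this assay, which is the lowest of the two numbers, with compound 1 the nearest. The one measured step, a number 1.4 percentage points lower from compound 1 to compound 2 (within the scatter), lies within the scatter, so on the numbers shown the two compounds are indistinguishable.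

Compound 3 `COc1ccccc1-c1cn2ccnc2c(-c2ccc3ncn(C4CCCCC4)c3c2)n1` is the next one to be measured. It differs from compound 2 in a single place: 2-methoxyphenyl in place of 4-bromophenyl on an aromatic carbon. Going by the values given here, no measured step covers this kind of change; the only step available swaps one halogen for another on the same ring, and that step was within the scatter. There is therefore no basis for expecting compound 3 to move beyond the scatter in either direction, and the expected step of a number 1.1 percentage points higher from compound 2 to compound 3 (within the scatter) is set near zero. For compound 3 the estimate in this assay is 10%, with a range from -3% to 25%.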

Compound 3, a percentage reported as inhibition, at one concentration (the size of the read-out at that concentration, not a potency): 6.61%
Compound 3: middle estimate off by 3.4 percentage points, on the high side, within the range that was stated.
By their numbers in this assay, from the lowest: compounds 3, 2 and 1 (each within the scatter of the next).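

The step from the halogen swap covered only a change on the same 4-substituted phenyl ring, whereas the new steps replace that ring with 2-methoxyphenyl at this position on the six-membered aromatic ring with 2 nitrogen: a number 2.3 percentage points lower from compound 2 to compound 3 (within the scatter) and a number 3.7 percentage points lower from compound 1 to compound 3 (within the scatter), both in this assay. Both steps lie within the scatter, so 4-fluorophenyl, 4-bromophenyl and 2-methoxyphenyl cannot be told apart here, even though the change alters the substitution pattern on the phenyl ring and adds a hydrogen-bond acceptor. No supporting evidence bears on this result, so it stands as an observation without an explanation.

The compounds shown leave open whether any group at this position can move the read-out beyond the scatter, for example a phenyl ring carrying an amine or a carboxylic acid, or a longer chain in place of the phenyl ring. For the compounds shown here, they also leave open whether the cyclohexyl group, common to all three compounds, has any bearing on the read-out, as no step covers a change there.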